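Swapping the Amide Aryl Group: Fluorine Replaces Ethyl

The compounds below may be only part of what the source reports. "The series", "measured", "known", "first", "only" and "open" are said of these compounds alone.

Three compounds share one core and differ only in the aryl group attached to an amide-type nitrogen. Compound 1 `O=C(CSc1nc(Nc2ccccc2)c2ccccc2n1)Nc1ccccc1Br` carries a 2-bromophenyl there, and in a functional assay on MDA-MB-231 cells (Homo sapiens) for inhibition, read by MTT assay, with a stated time of 72 h (on this read-out lower numbers stand for stronger inhibition and higher numbers for weaker inhibition), compound 1 gives 14100 nM. Compound 2 `O=C(CSc1nc(Nc2ccccc2)c2ccccc2n1)Nc1cccc([N+](=O)[O-])c1` carries a 3-nitrophenyl, and in this assay compound 2 gives 33000 nM. Compound 3 `CCc1cccc(NC(=O)CSc2nc(Nc3ccccc3)c3ccccc3n2)c1` carries a 3-ethylphenyl, and in this assay compound 3 gives 12400 nM. Among the compounds with values here, compound 3 stands at the low end of the three numbers, but the step of a 1.1-fold lower number from compound 1 to compound 3 (0.06 log units; within the scatter) lies within the scatter, so compound 1 and compound 3 are not distinguished; only the step of a 2.7-fold lower number from compound 2 to compound 3 (0.43 log units; beyond the scatter) is a real difference, and a 2.3-fold higher number from compound 1 to compound 2 (0.37 log units; beyond the scatter) shows the same picture from the other side.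

Compound 4 `O=C(CSc1nc(Nc2ccccc2)c2ccccc2n1)Nc1ccc(F)cc1` differs from compound 3 by one change: 4-fluorophenyl in place of 3-ethylphenyl on an amide-type nitrogen. Within the data shown here, the steps that bear on it are the two that alter the same aryl group, a 1.1-fold lower number from compound 1 to compound 3 (0.06 log units; within the scatter) within the scatter and a 2.7-fold lower number from compound 2 to compound 3 (0.43 log units; beyond the scatter) modest. All three measured aryl groups stay within a narrow band, so for compound 4 the expected step of a 1.2-fold higher number from compound 3 to compound 4 (0.08 log units; within the scatter) is small, most likely within the scatter. The estimate for compound 4 in this assay is 15000 nM, with a range from 7000 nM to 35000 nM.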

Compound 4, half-maximal inhibitory concentration: 34100 nM
Compound 4: middle estimate off by 2.3-fold (0.36 log units), on the low side; the range from low to high includes it.
By their numbers in this assay, from the lowest: compounds 3 and 1 (each within the scatter of the next); then compounds 2 and 4 (each within the scatter of the next).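

In this assay the aryl group on this amide-type nitrogen now sorts the four compounds into two pairs: the step of a 2.8-fold higher number from compound 3 to compound 4 (0.44 log units; beyond the scatter) and the step of a 2.4-fold higher number from compound 1 to compound 4 (0.38 log units; beyond the scatter) are both modest but beyond the scatter, whereas the step of a 1.0-fold higher number from compound 2 to compound 4 (0.01 log units; within the scatter) lies within it. Until now the 3-nitrophenyl of compound 2 stood alone at its level, but the 4-fluorophenyl of compound 4 shares that level, so a single change from 3-ethylphenyl to 4-fluorophenyl is enough to separate compound 4 from compound 3. Nothing measured here gives a reason why the 3-nitrophenyl and 4-fluorophenyl groups land together or why the 2-bromophenyl and 3-ethylphenyl groups do.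

The step from compound 3 to compound 4 alters both the substituent and the number in the group's name, so these compounds cannot separate the effect of swapping ethyl for fluorine from the effect of its placement on the ring. They also leave open how 3-fluorophenyl, 4-ethylphenyl, or a phenyl group carrying an amine or a carboxylic acid would behave on this nitrogen.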